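The compounds below may be only part of what the source reports. "The series", "measured", "known", "first", "only" and "open" are said of these compounds alone.

In a functional assay on MCF7 cells (Homo sapiens) for antiproliferative activity, read by MTT assay, with a stated time of 24 h (a higher number here means a weaker inhibitor, a lower number a stronger inhibitor), compound 1 (`CCCCc1oc2ccccc2c1C(=O)c1ccc(OCC(=O)N2CCCC2)cc1`) gives 42400 nM, compound 2 (`CCCCc1oc2ccccc2c1C(=O)c1ccc(OCC(=O)NCc2ccccc2)cc1`) gives 19600 nM and compound 3 (`CCCCc1oc2ccccc2c1C(=O)c1ccc(OCC(=O)N[C@H](C)c2ccccc2)cc1`) gives 14100 nM. Compound 3 shares the low end of these numbers with compound 2. The steps there are a 1.4-fold lower number from compound 2 to compound 3 (0.14 log units; within the scatter) and a 3.0-fold lower number from compound 1 to compound 3 (0.48 log units; beyond the scatter), and the remaining step is a 2.2-fold lower number from compound 1 to compound 2 (0.34 log units; beyond the scatter).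

Compound 4 (`CCCCc1oc2ccccc2c1C(=O)c1ccc(OCCCC(=O)N2CCCC2)cc1`) follows from 2-((pyrrolidin-1-yl)carbonyl)ethyl in place of (1-phenylethyl)carbamoyl on a saturated chain carbon bound to an oxygen on an aromatic ring. This restores the pyrrolidin-1-yl amide of compound 1, so the closest evidence is a 3.0-fold lower number from compound 1 to compound 3 (0.48 log units; beyond the scatter), read in reverse. For the measured compounds named here, no measured step covers the chain change. A modest rise in this assay is therefore expected. The expected step is a 2.5-fold higher number from compound 3 to compound 4 (0.39 log units; beyond the scatter). For compound 4 the estimated value is 35000 nM, with an expected range of 14000 nM to 85000 nM.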

Compound 4, half-maximal inhibitory concentration: 23500 nM
Compound 4: the middle estimate sits 1.5-fold (0.17 log units) above what was measured; low and high end bracket the measured number.
By their numbers in this assay, from the lowest: compounds 3, 2, 4 and 1 (each within the scatter of the next, the first and the last beyond it).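

In this assay, the 2-((pyrrolidin-1-yl)carbonyl)ethyl group at this place stays within the scatter of the (pyrrolidin-1-yl)carbonyl group of compound 1 (a 1.8-fold lower number from compound 1 to compound 4 (0.26 log units; within the scatter)). It also stays within the scatter of both the benzylcarbamoyl and (1-phenylethyl)carbamoyl groups (a 1.2-fold higher number from compound 2 to compound 4 (0.08 log units; within the scatter); a 1.7-fold higher number from compound 3 to compound 4 (0.22 log units; within the scatter)), so the separation that compound 1 shows from those two is not seen for compound 4. No evidence at hand bears on this result. Open, going by these compounds, is how benzylcarbamoyl behaves when carried on the chain of compound 4. Also open, on these data alone, is whether a carboxylic acid or a longer chain at this place stays in the same range.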